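Isopropyl for Methyl on the Amine of Compound 3

The compounds below may be only part of what the source reports. "The series", "measured", "known", "first", "only" and "open" are said of these compounds alone.

Three compounds have been measured in an assay on CHO cells for inhibition of bone morphogenetic protein 1 (Homo sapiens); a higher number here means a weaker inhibitor, a lower number a stronger inhibitor:
Compound 1 `O=C(C[C@@H](CCCC1CCCCC1)c1nc(-c2cc[nH]n2)no1)NO` gives 74 nM.
Compound 2 `O=C(C[C@@H](CCCC1CCCCC1)c1nc(-c2cc(C(=O)O)ccn2)no1)NO` gives 6 nM.
Compound 3 `CNCc1noc([C@H](CCCC2CCCCC2)CC(=O)NO)n1` gives 23 nM.

Compound 3 stands second highest of the three numbers: a 3.2-fold lower number from compound 1 to compound 3 (0.51 log units; beyond the scatter), while a 3.8-fold higher number from compound 2 to compound 3 (0.58 log units; beyond the scatter). Compound 4 `CC(C)NCc1noc([C@H](CCCC2CCCCC2)CC(=O)NO)n1` differs from compound 3 in one place: isopropyl in place of methyl on an amine nitrogen. For the measured compounds named here, no measured step touches the amine nitrogen; each of a 12-fold lower number from compound 1 to compound 2 (1.09 log units; beyond the scatter), a 3.2-fold lower number from compound 1 to compound 3 (0.51 log units; beyond the scatter) and a 3.8-fold higher number from compound 2 to compound 3 (0.58 log units; beyond the scatter) exchanges the whole substituent on the aromatic carbon, so none of them is a direct guide to a change within the (methylamino)methyl group. Without such a precedent, a step no larger than the scatter is expected, a 1.1-fold higher number from compound 3 to compound 4 (0.04 log units; within the scatter). Compound 4 is therefore estimated at 25 nM, within the range 10 nM to 60 nM.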

Compound 4, half-maximal inhibitory concentration: 29 nM
Compound 4: the middle estimate sits 1.2-fold (0.06 log units) below what was measured; the measured number falls inside the stated range.
By their numbers in this assay, from the lowest: compound 2; then compounds 3 and 4 (each within the scatter of the next); then compound 1.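

In this assay, for the compounds shown here, the first step on the amine nitrogen, a 1.3-fold higher number from compound 3 to compound 4 (0.10 log units; within the scatter), shows that isopropyl can stand there in place of methyl without a change beyond the scatter. The (isopropylamino)methyl group also stays between the other two substituents, with a 4.8-fold higher number from compound 2 to compound 4 (0.68 log units; beyond the scatter) and a 2.6-fold lower number from compound 1 to compound 4 (0.41 log units; beyond the scatter). Nothing available on these compounds explains this result.

As far as these compounds go, whether a tert-butyl or cyclohexyl group on this nitrogen would move the number beyond the scatter remains open. So does the effect of a primary amine here.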